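A few compounds are considered here, and "the series" means these few. Any claim that something is new, unique, unknown or untested is made for them only; others in the source may bear on it.

Compound 1 `O=C(N[C@H]1CC[C@@H](c2ccccc2)CC1)c1[nH]c(=O)[nH]c(=O)c1NC1CCCC1`: 436000 nM
Compound 2 `O=C(N[C@H]1CC[C@@H](c2ccccc2)CC1)c1[nH]c(=O)[nH]c(=O)c1O`: 25000 nM

Going by the values given here, in an assay on isolated protein for inhibition of endothelial lipase (Homo sapiens), read by LC-MS, with a stated time of 2 h, in the presence of a further agent that is not named here (a lower number here means a stronger inhibitor, a higher number a weaker inhibitor), compound 2 gives 25000 nM, the lower of the two numbers measured; the single measured step, a 17-fold lower number from compound 1 to compound 2 (1.24 log units; beyond the scatter), separates it from compound 1. Compound 3 `CC(C)Cn1c(=O)[nH]c(C(=O)N[C@H]2CC[C@@H](c3ccccc3)CC2)c(O)c1=O` differs from compound 2 by isobutyl in place of hydrogen on an aromatic nitrogen. Among the compounds with values here, the measured step concerns a change at a ring carbon, not at this ring nitrogen, so it offers no direct guide, and no other pair bears on the change. With nothing to argue for movement, compound 3 is expected to fall near compound 2, at 25000 nM, within a range of 7000 nM to 90000 nM. That estimate means a step of no change at the digits printed from compound 2 to compound 3 (within the scatter), within the scatter.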

Compound 3, half-maximal inhibitory concentration: 48000 nM
The estimate for compound 3 lay 1.9-fold (0.28 log units) below the measured number, within the range that was stated.
By their numbers in this assay, from the lowest: compounds 2 and 3 (each within the scatter of the next); then compound 1.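

In this assay, the step shows a 1.9-fold higher number from compound 2 to compound 3 (0.28 log units; within the scatter) for isobutyl in place of hydrogen on this aromatic nitrogen. This ring nitrogen therefore carries isobutyl with no difference beyond the scatter, which the earlier change at a ring carbon could not show. Nothing available here accounts for this result. The compounds shown leave open whether a longer chain, an amine or a carboxylic acid on this nitrogen would also stay within the scatter of compound 2.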